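The compounds below may be only part of what the source reports. "The series", "measured", "known", "first", "only" and "open" are said of these compounds alone.

In a functional assay on HL-60 cells (Homo sapiens) for inhibition, read by CCK-8 assay, with a stated time of 48 h (a higher number here means a weaker inhibitor, a lower number a stronger inhibitor), compound 1 `Cc1cc(C)cc(NC(=O)NCCNS(=O)(=O)c2ccc(-c3ccccc3Oc3ccc([N+](=O)[O-])c([N+](=O)[O-])c3)s2)c1` gives 9100 nM. Compound 2 `O=C(NCCNS(=O)(=O)c1ccc(-c2ccccc2O[C@H]2CC[C@@H](O)CC2)s1)Nc1ccc([N+](=O)[O-])cc1` reads > 20000 nM, which is a limit of the assay and not a number. Compound 3 `O=[N+]([O-])c1ccc(NC(=S)NCCNS(=O)(=O)c2ccc(-c3ccccc3O[C@H]3CC[C@@H](O)CC3)s2)cc1` reads > 50000 nM, and this too is a limit. The move to compound 4 `O=[N+]([O-])c1ccc(NC(=S)NCCNS(=O)(=O)c2ccc(-c3ccccc3O[C@H]3CC[C@H](O)CC3)s2)cc1` is this: the two compounds have the same atoms and bonds and differ only in configuration as drawn: 2 of 2 stereo elements differ (all stereocentres are inverted: mirror images); a stereocentre at a saturated ring carbon is drawn s in compound 3 and r in compound 4; a stereocentre at a saturated ring carbon is drawn s in compound 3 and r in compound 4. The two compounds share the same atoms and bonds, and all stereocentres are inverted. Within the data shown here, the only measured step that touches compound 3, a step that the two limits leave unreadable from compound 2 to compound 3, has no readable size and involves no change of configuration, so it offers nothing to carry over. The estimated step, a number no higher from compound 3 to compound 4 (the limit leaves the size open), is therefore expected to stay within the scatter, with no direction favoured. For compound 4 the estimate is 50000 nM, with an expected range from 20000 nM to 120000 nM.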

Compound 4, half-maximal inhibitory concentration: 11600 nM
Compound 4: middle estimate off by 4.3-fold (0.63 log units), on the high side; measured number below the stated range.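

Configuration at the two saturated ring carbons matters for this scaffold, a point the earlier compounds could not show: in this assay there is an at least 4.3-fold lower number from compound 3 to compound 4 (0.63 log units; beyond the scatter), a real change in the number. Compound 3 reads > 50000 nM, which is a limit of the assay and not a number. The step can be put down to configuration alone, because nothing else changes: the fact that compounds 3 and 4 differ only in the configuration as drawn.

As far as these compounds go, it remains open whether the same inversion would matter with the carbonyl linker of compound 2. From the compounds shown here alone, it also remains open whether an amine in place of the hydroxyl on the saturated ring would keep this difference.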